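Naphthalenyl for formylphenyl on the benzyl-bearing core

The source may report more compounds than this note shows. Statements on the series, on what has been measured and on what is new or still open speak of the compounds shown alone.

Compound 1 `O=Cc1ccc(-c2cn3ccnc3c(-c3ccc4ncn(C5CCCCC5)c4c3)n2)cc1` gives 14.4% in a functional assay on SNB-19 cells (Homo sapiens) for inhibition, read by sulforhodamine B assay, with a stated time of 48 h, tested at 10 uM; a lower number here means less inhibition, a higher number more inhibition at the concentration tested (going by the name of the read-out). Compound 2 `c1ccc2c(-c3cn4ccnc4c(-c4ccc5ncn(C6CCCCC6)c5c4)n3)cccc2c1` differs from compound 1 by naphthalen-1-yl in place of 4-formylphenyl on an aromatic carbon, and in this assay compound 2 gives 9.08%; the step is a number 5.3 percentage points lower from compound 1 to compound 2 (within the scatter). Compound 3 `O=Cc1ccc(-c2cn3ccnc3c(-c3ccc4ncn(Cc5ccccc5)c4c3)n2)cc1` differs from compound 1 by benzyl in place of cyclohexyl on an aromatic nitrogen; in this assay compound 3 gives 14.4%, and the step is no change at the digits printed from compound 1 to compound 3 (within the scatter). Compound 3 and compound 1 thus stand level, and both are within the scatter of compound 2, so the three measured numbers show no difference that can be trusted.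

Compound 4 `c1ccc(Cn2cnc3ccc(-c4nc(-c5cccc6ccccc56)cn5ccnc45)cc32)cc1` has not yet been measured in this assay. It differs from compound 3 by naphthalen-1-yl in place of 4-formylphenyl on an aromatic carbon. The surroundings of the place are described in the same words for the earlier change and for this one, so the change is the same, made once on each of two cores; the two cores differ by benzyl in place of cyclohexyl on an aromatic nitrogen. For the measured compounds named here, the one earlier instance of this change gave a number 5.3 percentage points lower from compound 1 to compound 2 (within the scatter), a step that lies within the scatter, and the two cores themselves gave a step within the scatter.

Going by the values given here, the step from compound 3 to compound 4 is therefore expected to be a number 4.9 percentage points lower from compound 3 to compound 4 (within the scatter), resting on the single earlier instance and carrying its uncertainty. Compound 4 is expected to give about 9.5% in this assay, with a likely range from 0% to 22%.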

Compound 4, a percentage reported as inhibition, at one concentration (the size of the read-out at that concentration, not a potency): 5.12%
For compound 4 the middle estimate is 4.4 percentage points above the measured one, within the range that was stated.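

Carried onto the benzyl-bearing core, naphthalen-1-yl in place of 4-formylphenyl gives in this assay a number 9.3 percentage points lower from compound 3 to compound 4 (within the scatter), and this step agrees with the earlier instance of the same change: the same change on two cores in this assay, a number 5.3 percentage points lower (within the scatter) from compound 1 to compound 2 and a number 9.3 percentage points lower (within the scatter) from compound 3 to compound 4, 4 percentage points apart, within the scatter of two such steps.

Benzyl in place of cyclohexyl, read on the pair carrying naphthalen-1-yl, gives a number 4 percentage points lower from compound 2 to compound 4 (within the scatter), and this step also agrees with its earlier instance: the same change on two cores in this assay, no change at the digits printed (within the scatter) from compound 1 to compound 3 and a number 4 percentage points lower (within the scatter) from compound 2 to compound 4, 4 percentage points apart, within the scatter of two such steps.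

This shows that neither change gives a detectably different step on the two cores, but it does not show that either change has a real effect, since all four steps lie within the scatter, and agreement among steps this small is weak support for carrying a step from one core to another.

The compounds shown cover only 4-formylphenyl and naphthalen-1-yl on the aromatic carbon, and cyclohexyl and benzyl on the aromatic nitrogen, so it stays open whether an amine, a carboxylic acid or a longer alkyl chain at either place would move the number in this assay beyond the scatter. It also stays open whether a change of that larger size would carry from one core to the other, and a reading at one concentration gives no potency for any of these compounds.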